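Aryl urea series: cytotoxicity read-outs and one open compound

The source may hold more compounds than are shown below. What is called first, only, known or untested is meant among the compounds shown, and "the series" means these compounds.

Within the data shown here, all values so far come from an ADME assay on Raji cells (Homo sapiens) for cytotoxicity, with a stated time of 72 h; on this read-out higher numbers stand for an effect only at larger amounts of compound and lower numbers for an effect already at smaller amounts.
Compound 1 `Cc1cc(NC(=O)Nc2ccc(C(C)(C)C)cc2)c2ccccc2n1` gives, as a limit of the assay rather than a number, > 25000 nM.
Compound 2 `CSc1ccc(NC(=O)Nc2cc(C)nc3ccccc23)cc1` gives, as a limit of the assay rather than a number, > 25000 nM.
Compound 3 `Cc1cc(NC(=O)Nc2ccccc2C(C)(C)C)c2ccccc2n1` gives, as a limit of the assay rather than a number, > 25000 nM.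

In this assay nothing has yet been resolved: the limit of > 25000 nM in this assay, at which 3 of the 3 values shown sit. Compound 1 and compound 2 differ by one change, (methylsulfanyl in place of tert-butyl on an aromatic carbon), and the step that the two limits leave unreadable from compound 1 to compound 2 cannot be sized because the limit of > 25000 nM in this assay, at which 3 of the 3 values shown sit, holds both ends. Compound 3 is built from the same atoms as compound 1, joined differently; the difference between the two cores is not broken down here.

Compound 4 `CSc1ccccc1NC(=O)Nc1cc(C)nc2ccccc12` is not yet measured. It arises from compound 3 by methylsulfanyl in place of tert-butyl on an aromatic carbon. This is the same kind of change as from compound 1 to compound 2, not the same one: there the group enters para to a large group, here ortho to a large group.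

Among the measured compounds shown here, for compound 4 in this assay the step that the limit leaves unreadable from compound 3 to compound 4 is expected to stay within the scatter, because the one measured instance of this change, a step that the two limits leave unreadable from compound 1 to compound 2, left both compounds at the limit of > 25000 nM in this assay, at which 3 of the 3 values shown sit. Compound 4 is accordingly estimated at 40000 nM, most likely reported again only as a limit.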

Compound 4, half-maximal effective concentration: > 25000 nM
Compound 4: no number, only a limit (the forecaster's own chance of this, stated with the estimate: 85%); the middle value is on the limit's open side.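

No step can be read from compound 3 to compound 4 in this assay, as both ends remain limits of the assay rather than numbers: the limit of > 25000 nM in this assay, at which 4 of the 4 values shown sit.

The compounds shown leave open whether methylsulfanyl in place of tert-butyl on an aromatic carbon changes the read-out in this assay at all, and how large any such step would be.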